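The source may report more compounds than this note shows. Statements on the series, on what has been measured and on what is new or still open speak of the compounds shown alone.

In a functional assay on DU-145 cells (Homo sapiens) for inhibition, read by trypan blue exclusion, with a stated time of 96 h (on this read-out lower numbers stand for stronger inhibition of growth and higher numbers for weaker inhibition of growth), three compounds built on the shared core have been measured. Compound 1 (`Cc1ccc(/C=C(/SCc2ccc(Cl)cc2Cl)C(=O)c2ccc(Cl)cc2)s1`) gives 50000 nM, compound 2 (`Cc1ccc(CS/C(=C/c2ccc(O)c(O)c2O)C(=O)c2ccc(Cl)cc2)cc1`) gives 50000 nM, and compound 3 (`COc1ccccc1/C=C(/SCc1ccc(C)cc1)C(=O)c1ccc(Cl)cc1`) gives 10000 nM. Compound 3 thus has the lowest number of the three and the strongest inhibition of growth so far.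

Compound 4 (`Cc1ccc(CS/C(=C/c2ccc(C)s2)C(=O)c2ccc(Cl)cc2)cc1`), not yet measured, differs from compound 3 in one place: 5-methylthiophen-2-yl in place of 2-methoxyphenyl on a double-bonded chain carbon bound to a double-bonded chain carbon. Among the measured compounds shown here, the only measured step at this place is a 5.0-fold lower number from compound 2 to compound 3 (0.70 log units; beyond the scatter). It is modest and beyond the scatter, but it involves other groups, so it offers only a rough guide to size. A closer hint comes from the 5-methylthiophen-2-yl that compound 4 shares with compound 1, and compound 1 reads 50000 nM. Compound 1 also differs from compound 4 elsewhere, so this value cannot be carried over directly.

On this evidence, a modest step towards a higher number, meaning weaker inhibition of growth, is expected in this assay. The expected change is a 2.5-fold higher number from compound 3 to compound 4 (0.40 log units; beyond the scatter). Compound 4 is estimated at 25000 nM, with an expected range of 8000 nM to 60000 nM.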

Compound 4, concentration for 50% growth inhibition: 50000 nM
Beside the measured number, compound 4's estimate is 2.0-fold (0.30 log units) below it, and the stated range covers the measured number.
By their numbers in this assay, from the lowest: compound 3; then compounds 1, 2 and 4 (each within the scatter of the next).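

In this assay the change to 5-methylthiophen-2-yl on a double-bonded chain carbon bound to a double-bonded chain carbon gives a 5.0-fold higher number from compound 3 to compound 4 (0.70 log units; beyond the scatter) and thus shows that a ring without the 2,3,4-trihydroxyphenyl hydroxyl groups does not by itself keep the lower number seen with 2-methoxyphenyl. At the same place, 5-methylthiophen-2-yl in place of 2,3,4-trihydroxyphenyl gives no change at the digits printed from compound 2 to compound 4 (within the scatter) in this assay and so sets these two quite different rings level, leaving 2-methoxyphenyl as the only group shown here that stands apart, while 4-methylphenyl in place of 2,4-dichlorophenyl on a saturated chain carbon bound to a sulfur gives no change at the digits printed from compound 1 to compound 4 (within the scatter) with the 5-methylthiophen-2-yl in place. The data shown offer no measurement that would account for these results.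

Going by these compounds, what remains open is whether the lower number of compound 3 depends on the methoxy group or on the six-membered aromatic ring, a question that a plain phenyl group or a pyridine ring at this place would address. On these data alone, it is also open whether 2-methoxyphenyl would keep its edge with 2,4-dichlorophenyl on the saturated chain carbon bound to a sulfur.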